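The source may report more compounds than this note shows. Statements on the series, on what has been measured and on what is new or still open speak of the compounds shown alone.

Working notes on the series, read in a functional assay on A549 cells (Homo sapiens) for inhibition, read by CCK-8 assay, with a stated time of 72 h, tested at 8 uM; on this read-out higher numbers stand for more inhibition of growth at the one concentration tested and lower numbers for less inhibition of growth. Compound 1 (`CCc1ccc(SCc2ccc(C(=O)Nc3ccccc3N)cc2)cc1`) gives 91.4%, compound 2 (`Nc1ccccc1NC(=O)c1ccc(CSc2cccc(F)c2)cc1`) gives 72.7% and compound 3 (`Cc1ccc(SCc2ccc(C(=O)Nc3ccccc3N)cc2)cc1`) gives 78.3%. Compound 3 therefore lies in the group's lower pair, with a number 5.6 percentage points higher from compound 2 to compound 3 (within the scatter) staying within the scatter, while a number 13.1 percentage points lower from compound 1 to compound 3 (beyond the scatter) lies beyond it.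

Compound 4 (`Nc1ccccc1NC(=O)c1ccc(CSCCc2ccccc2)cc1`) carries phenethyl in place of 4-methylphenyl on a sulfur. The measured steps that bear on this change are those that alter the group on the sulfur. These are a number 18.7 percentage points lower from compound 1 to compound 2 (beyond the scatter) and a number 13.1 percentage points lower from compound 1 to compound 3 (beyond the scatter), both modest, along with the step within the scatter already noted. Within the data shown here, none of the measured compounds carries phenethyl, so the data offer no direct precedent and the direction is uncertain. A modest fall in this assay is the working expectation, similar in size to those two steps. The expected change is a number 12.3 percentage points lower from compound 3 to compound 4 (beyond the scatter). Compound 4 is estimated at 66%, with an expected range of 45% to 85%.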

Compound 4, percent growth inhibition at one concentration: 84.1%
Compound 4: the middle estimate sits 18.1 percentage points below what was measured; low and high end bracket the measured number.
By their numbers in this assay, from the lowest: compounds 2, 3, 4 and 1 (each within the scatter of the next, the first and the last beyond it).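

Among these compounds, the sulfur accepts phenethyl, the first group that is not a substituted phenyl, without a loss in this assay: a number 5.8 percentage points higher from compound 3 to compound 4 (within the scatter) and a number 7.3 percentage points lower from compound 1 to compound 4 (within the scatter) both stay within the scatter. The change registers only against 3-fluorophenyl, with a number 11.4 percentage points higher from compound 2 to compound 4 (beyond the scatter), so among these compounds a substituted phenyl on the sulfur is not needed for this level of growth inhibition. No measurement at hand accounts for these steps.

On these data alone, it remains open whether benzyl or the longer phenylpropyl on the sulfur would hold this level, and whether an amine or a carboxylic acid at the end of the chain would be accepted. Readings at a single concentration also leave open how far these compounds differ in potency.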